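A few compounds are considered here, and "the series" means these few. Any claim that something is new, unique, unknown or untested is made for them only; others in the source may bear on it.

Measured so far in an ADME assay on C8166 cells (Homo sapiens) for cytotoxicity, read by MTT assay; on this read-out lower numbers stand for higher toxicity in this test and higher numbers for lower toxicity in this test
- compound 1 `CCCn1cc(C(=O)O)c(=O)c2c(O)c(Cc3cccc(Cl)c3F)ccc21` gives 24200 nM
- compound 2 `CC(C)n1cc(C(=O)O)c(=O)c2c(O)c(Cc3cccc(Cl)c3F)ccc21` gives 26500 nM
- compound 3 `O=C(O)c1cn(C2CC2)c2ccc(Cc3cccc(Cl)c3F)c(O)c2c1=O` gives 39100 nM

Compound 1 shows no separation from the other two: a 1.1-fold higher number from compound 1 to compound 2 (0.04 log units; within the scatter) and a 1.6-fold higher number from compound 1 to compound 3 (0.21 log units; within the scatter) and also a 1.5-fold higher number from compound 2 to compound 3 (0.17 log units; within the scatter) all lie within the scatter. Compound 4 `O=C(O)c1cn(C2CCCC2)c2ccc(Cc3cccc(Cl)c3F)c(O)c2c1=O` is not yet measured. Relative to compound 1 it has cyclopentyl in place of propyl on an aromatic nitrogen, with the rest of the core unchanged: cyclopentyl in place of propyl on an aromatic nitrogen is the counted difference. The three measured steps all exchange the group on this same nitrogen, so they are the relevant evidence, but none of them involves cyclopentyl and the bearing is indirect. No step beyond the scatter is therefore expected in this assay for this change. The expected step is a 1.0-fold higher number from compound 1 to compound 4 (0.01 log units; within the scatter) and no larger trend is assumed. Compound 4 is estimated at 25000 nM with 13000 nM to 45000 nM as the expected range.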

Compound 4, half-maximal cytotoxic concentration: 12400 nM
The estimate for compound 4 lay 2.0-fold (0.30 log units) above the measured number; the measured number lies below the stated range.
By their numbers in this assay, from the lowest: compounds 4, 1, 2 and 3 (each within the scatter of the next, the first and the last beyond it).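

In this assay, the group on this aromatic nitrogen now produces steps beyond the scatter, which the exchanges among propyl, isopropyl and cyclopropyl did not: a 3.2-fold lower number from compound 3 to compound 4 (0.50 log units; beyond the scatter) and a 2.1-fold lower number from compound 2 to compound 4 (0.33 log units; beyond the scatter), both modest. The separation is incomplete, since a 2.0-fold lower number from compound 1 to compound 4 (0.29 log units; within the scatter) remains within the scatter, so cyclopentyl stands apart from isopropyl and cyclopropyl but not from propyl. Nothing available explains how cyclopentyl differs from the other groups at this position.

From the compounds shown here alone, whether the separation goes with the ring or with the larger carbon count remains open, and a straight pentyl chain, a cyclobutyl ring or a cyclohexyl ring on this nitrogen would help distinguish the two. Also open, going by these compounds, is how a group carrying an amine or a hydroxyl at this position would read in this assay.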